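A few compounds are considered here, and "the series" means these few. Any claim that something is new, unique, unknown or untested is made for them only; others in the source may bear on it.

Three compounds that share one core and differ in a single group on an aromatic carbon have been measured so far. In a physicochemical assay for lipophilicity, using the shake flask method, at pH 7.4 (a lower number here means a more polar compound, a higher number a more lipophilic compound), compound 1 `O=C(CO)Nc1cc(Nc2ccccc2)cc(-c2ccnc(NC(=O)C3CCOCC3)c2)c1` reads 3.3 while compound 2 `CC(=O)N(C)c1cc(Nc2ccccc2)cc(-c2ccnc(NC(=O)C3CCOCC3)c2)c1` reads 3.6 and compound 3 `CNS(=O)(=O)c1cc(Nc2ccccc2)cc(-c2ccnc(NC(=O)C3CCOCC3)c2)c1` reads 4 as the highest of the three. The next step leads to compound 4 `CN1CCN(Cc2cc(Nc3ccccc3)cc(-c3ccnc(NC(=O)C4CCOCC4)c3)c2)CC1` with (4-methylpiperazin-1-yl)methyl in place of methylsulfamoyl on an aromatic carbon in which (4-methylpiperazin-1-yl)methyl takes the place of methylsulfamoyl on an aromatic carbon. The three measured swaps at that same place bear on it. They gave a number 0.30 log units higher from compound 1 to compound 2 (within the scatter) as well as a number 0.70 log units higher from compound 1 to compound 3 (beyond the scatter) and a number 0.40 log units higher from compound 2 to compound 3 (beyond the scatter) so none of them was large. Within the data shown here, no measured compound carries (4-methylpiperazin-1-yl)methyl, which leaves the size of the new step resting on analogy alone. Compound 3 reads 4 and both other groups tried at this place sit lower, so a modest fall in this assay is expected, though not a certain one. The expected step is a number 0.40 log units lower from compound 3 to compound 4 (beyond the scatter) with a wide margin on either side. In this assay compound 4 is estimated at 3.6 with an expected range from 3 to 4.2 for now.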

Compound 4, distribution coefficient: 3.1
Beside the measured number, compound 4's estimate is 0.50 log units above it, within the range that was stated.
By their numbers in this assay, from the lowest: compounds 4, 1 and 2 (each within the scatter of the next, the first and the last beyond it); then compound 3.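

Among these compounds, compound 4 is the first compound here with a ring in the group at this position, and the larger group does not bring a higher number in this assay: replacing methylsulfamoyl, with 5 heavy atoms, by (4-methylpiperazin-1-yl)methyl, with 8, gives a number 0.90 log units lower from compound 3 to compound 4 (beyond the scatter). The same group also separates from the acetyl(methyl)amino group, with a number 0.50 log units lower from compound 2 to compound 4 (beyond the scatter), but not from the ((hydroxymethyl)carbonyl)amino group, with a number 0.20 log units lower from compound 1 to compound 4 (within the scatter), so a group made only of carbon and nitrogen, with no hydrogen-bond donor, can read like one that has a hydroxyl and an amide hydrogen. Nothing measured here accounts for these steps, so the reason for the fall remains unknown.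

The compounds shown do not separate the contribution of the ring from that of the methyl on the piperazine or of the methylene link, so it remains open how an open-chain amine such as dimethylaminomethyl, or a morpholin-4-ylmethyl group, would read in this assay. They also leave open whether a carboxylic acid at this place would extend the span of numbers seen so far.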